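Aryl swap on the ring amine: expectation for compound 4

The source may report more compounds than this note shows. Statements on the series, on what has been measured and on what is new or still open speak of the compounds shown alone.

Measured compounds:
compound 1, `Nc1scc(CN2CCN(c3ccc(OC(F)(F)F)cc3)CC2)c1C(=O)c1ccc(Cl)cc1`: -74%
compound 2, `Nc1scc(CN2CCN(c3cccc4ccccc34)CC2)c1C(=O)c1ccc(Cl)cc1`: -21%
compound 3, `Nc1scc(CN2CCN(c3ccccc3Cl)CC2)c1C(=O)c1ccc(Cl)cc1`: -18%

In a functional assay on CHO cells with adenosine receptor A1 (Homo sapiens) as the target, read by cAMP accumulation and immunoassay, with a stated time of 6 min, tested at 10 uM (on this read-out higher numbers stand for a weaker effect at the one concentration tested and lower numbers for a stronger effect), compound 1 gives -74%, the lowest number of the three. Compound 2 gives -21% and compound 3 gives -18%; the step from compound 2 to compound 3 is a number 3 percentage points higher from compound 2 to compound 3 (within the scatter), so these two are not told apart. Both changes away from the aryl group of compound 1 moved the number far upward: a number 53 percentage points higher from compound 1 to compound 2 (beyond the scatter) and a number 56 percentage points higher from compound 1 to compound 3 (beyond the scatter).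

Compound 4, `Nc1scc(CN2CCN(c3cc(Cl)ccc3Cl)CC2)c1C(=O)c1ccc(Cl)cc1`, is unmeasured. It differs from compound 1 by 2,5-dichlorophenyl in place of 4-(trifluoromethoxy)phenyl on an amine nitrogen in a ring. The two measured steps from compound 1 bear on this: exchanging the 4-(trifluoromethoxy)phenyl for either naphthalen-1-yl or 2-chlorophenyl on the amine nitrogen in a ring raised the number by a large amount, and the 2-chlorophenyl case of compound 3 is the closer comparison. A large upward step is therefore expected for compound 4, a number 52 percentage points higher from compound 1 to compound 4 (beyond the scatter). Compound 4 is expected to give about -22% in this assay, within a range from -48% to 2%, on the evidence of compound 3 at -18% and compound 2 at -21%.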

Compound 4, a percentage reported as activity, at one concentration (the size of the read-out at that concentration, not a potency): -62%
Estimate against measurement, compound 4: 40 percentage points above; measured number below the stated range.
By their numbers in this assay, from the lowest: compound 1; then compound 4; then compounds 2 and 3 (each within the scatter of the next).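

On the aryl group on the amine nitrogen in the ring, one chloro in place of hydrogen on an aromatic carbon is enough to shift the read-out in this assay by a large amount (a number 44 percentage points lower from compound 3 to compound 4 (beyond the scatter)), so a 2-chlorophenyl group does not by itself fix the number at this place. The 2,5-dichlorophenyl group also stands apart from naphthalen-1-yl (a number 41 percentage points lower from compound 2 to compound 4 (beyond the scatter)) and only a modest step from 4-(trifluoromethoxy)phenyl (a number 12 percentage points higher from compound 1 to compound 4 (beyond the scatter)), which shows that a large upward step is not the general outcome of replacing that group and that a low number here does not require its oxygen or fluorine atoms. Nothing at hand accounts for these differences.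

Still open, as far as these compounds go, is whether the second chloro itself matters or whether another small group would serve in its place, such as a methyl, a methoxy or a nitrile. These single-concentration read-outs also leave open whether the order of compound 1, compound 4 and the rest would hold across a range of concentrations, and whether a trifluoromethyl in place of the trifluoromethoxy would keep the number of compound 1.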